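The source may report more compounds than this note shows. Statements on the series, on what has been measured and on what is new or still open speak of the compounds shown alone.

Measured in an ADME assay on HCT-116 cells (Homo sapiens) for cytotoxicity, read by CellTiter-Glo, with a stated time of 72 h (on this read-out lower numbers stand for stronger inhibition and higher numbers for weaker inhibition), each entry a limit of the assay and not a number:
compound 1 `Cc1cc(C)c(S(=O)(=O)N2CCC(N3CCC(c4ccccc4)CC3)CC2)c(C)c1`: > 5000 nM
compound 2 `Cc1cc(C)c(S(=O)(=O)N2CCC(N3CCN(C)CC3)CC2)c(C)c1`: > 5000 nM
compound 3 `CCCC(=O)NC1CCN(S(=O)(=O)c2c(C)cc(C)cc2C)CC1`: > 5000 nM

Compound 3 stands only at a limit, > 5000 nM. Going by the values given here, compound 1 and compound 2 are limits as well, so the series so far offers no numerical value to build on.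

The next compound is compound 4 `Cc1cc(C)c(S(=O)(=O)N2CCC(N3CCC(O)CC3)CC2)c(C)c1`, which keeps the shared core of compound 3. The change is 4-hydroxypiperidin-1-yl in place of (propylcarbonyl)amino on a saturated ring carbon. In words, 4-hydroxypiperidin-1-yl replaces (propylcarbonyl)amino on a saturated ring carbon.

Among the compounds with values here, one measured step bears on this place: a step that the two limits leave unreadable from compound 2 to compound 3. Its size cannot be read because of the limit of > 5000 nM in this assay, at which 3 of the 3 values shown sit. It therefore supplies neither a magnitude nor a direction to carry over to the new group. All that the three compounds show is that none has yet given a number in this assay. On that basis, no step beyond the scatter is expected, in either direction. The expected step is a step that the limit leaves unreadable from compound 3 to compound 4, an estimate that rests on limits alone. Compound 4 is estimated at 7000 nM, with an expected range from 3000 nM to 20000 nM, and the assay is expected to report only a limit.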

Compound 4, half-maximal inhibitory concentration: > 5000 nM
Compound 4 was reported as a limit; the forecaster's own chance of this, stated with the estimate: 85%; the middle value does not contradict the limit.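

The steps from compound 4 to compound 1, compound 2 and compound 3 cannot be read in this assay, because all four entries are limits and not numbers: the limit of > 5000 nM in this assay, at which 4 of the 4 values shown sit.

The compounds shown leave open whether any group on this saturated ring carbon of the shared core gives a numerical value in this assay, and so the size and direction of any step.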